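A few compounds are considered here, and "the series" means these few. Any claim that something is new, unique, unknown or untested is made for them only; others in the source may bear on it.

Compound 3 `Clc1ccccc1COc1ccc(/C=C/C(/C=C/c2ccccn2)=N/Oc2ncnc3ccccc23)cc1` gives 10.1% in a functional assay on SMMC-7721 cells (Homo sapiens) for inhibition, read by MTT assay, with a stated time of 72 h, tested at 1 uM (a lower number here means a weaker effect, a higher number a stronger effect of the compound at the concentration tested), the lowest of the three numbers seen so far. Compound 1 `Clc1ccc2c(O/N=C(/C=C/c3ccc(OCc4ccccc4Cl)cc3)\C=C\c3ccccn3)ncnc2c1` gives 18.1% in this assay; the step of a number 8 percentage points lower from compound 1 to compound 3 (within the scatter) is within the scatter. Compound 2 `Cc1cccc(COc2ccc(/C=C/C(/C=C/c3ccccn3)=N/Oc3ncnc4cccc(C)c34)cc2)c1` gives 93.4%, beyond the scatter from compound 3, but compound 2 differs from compounds 3 and 4 in more than one place, so no single step can be read from it. Compound 4 `Cc1cccc2ncnc(O/N=C(/C=C/c3ccc(OCc4ccccc4Cl)cc3)\C=C\c3ccccn3)c12` differs from compound 3 by methyl in place of hydrogen on an aromatic carbon, quinazolin-4-yl to 5-methylquinazolin-4-yl. Going by the values given here, no measured step isolates this change; the only step on the core, chloro to hydrogen, stayed within the scatter. A step of a number 29.9 percentage points higher from compound 3 to compound 4 (beyond the scatter) is expected, though only loosely. Compound 4 is estimated at 40%, with a range from 8% to 85%.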

Compound 4, a percentage reported as inhibition, at one concentration (the size of the read-out at that concentration, not a potency): 77%
Beside the measured number, compound 4's estimate is 37 percentage points below it; low and high end bracket the measured number.
By their numbers in this assay, from the lowest: compounds 3 and 1 (each within the scatter of the next); then compound 4; then compound 2.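

In this assay, going by these compounds alone, the move from quinazolin-4-yl to 5-methylquinazolin-4-yl is the first change on the core to go beyond the scatter (  a number 66.9 percentage points higher from compound 3 to compound 4 (beyond the scatter)). Against the 7-chloroquinazolin-4-yl group the gain is similar (  a number 58.9 percentage points higher from compound 1 to compound 4 (beyond the scatter)), so this methyl, not chloro, marks the active compounds here. With the 5-methyl group held, replacing 3-methylphenyl by 2-chlorophenyl costs far less (  a number 16.4 percentage points lower from compound 2 to compound 4 (beyond the scatter)).

Going by these compounds, whether an ethyl, methoxy or amine group in place of this methyl keeps the gain remains open. Nothing shown bears on why the methyl has this effect.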